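A few compounds are considered here, and "the series" means these few. Any claim that something is new, unique, unknown or untested is made for them only; others in the source may bear on it.

Compound 1 `O=C(CCCCC#Cc1cccnc1)c1ncc(-c2ccccn2)o1` gives 300 nM in an assay for inhibition of Fatty-acid amide hydrolase 1 (Rattus norvegicus) (a higher number here means a weaker inhibitor, a lower number a stronger inhibitor), the higher of the two numbers measured, with compound 2 `O=C(CCCCC#Cc1ccc(Cl)cc1)c1ncc(-c2ccccn2)o1` at 20 nM. The change from compound 1 to compound 3 `O=C(CCCCSCc1ccccc1)c1ncc(-c2ccccn2)o1` is benzylsulfanyl in place of 2-(pyridin-3-yl)ethynyl on a saturated chain carbon, four bonds along the chain from a carbonyl carbon. Going by the values given here, only one measured step bears on it: a 15-fold lower number from compound 1 to compound 2 (1.18 log units; beyond the scatter), where the ring with a nitrogen gave way to a ring of carbon only while the triple bond stayed. Compound 3 also loses the ring nitrogen, but the triple bond is replaced by a different link, on which no measurement exists. A lower number is therefore expected, with an estimated step of a 3.0-fold lower number from compound 1 to compound 3 (0.48 log units; beyond the scatter), smaller than that measured step. Compound 3 is estimated at 100 nM, within 20 nM to 500 nM.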

Compound 3, inhibition constant: 25 nM
The estimate for compound 3 lay 4.0-fold (0.60 log units) above the measured number; the measured number falls inside the stated range.
By their numbers in this assay, from the lowest: compounds 2 and 3 (each within the scatter of the next); then compound 1.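

In this assay, the step of a 12-fold lower number from compound 1 to compound 3 (1.08 log units; beyond the scatter) shows that a triple bond is not needed on this chain for a much lower number: benzylsulfanyl has none, and its ring is of carbon only. Nothing measured here explains the change. Going by these compounds, the ring and the link changed together, so their separate shares stay open; pyridin-3-ylmethylsulfanyl would pair the ring nitrogen with the sulfur link. Also open, on these data alone, is how benzyloxy, with oxygen in place of sulfur, or a longer chain would compare.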